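Removing the tert-Butoxycarbonyl Group on Two Related Amides

This account rests on a few compounds, and the source may have more. Where it says the series, first, only, none or still open, it means among the compounds named here.

Compound 1 `CC(C)[C@H](NC(=O)c1cc(Cl)ccc1OCCCCNC(=O)OC(C)(C)C)C(=O)Nc1ccc([N+](=O)[O-])cc1Cl` was examined in a functional assay on MDA-MB-231 cells (Homo sapiens) for inhibition, read by MTT assay, with a stated time of 72 h; on this read-out lower numbers stand for stronger inhibition and higher numbers for weaker inhibition. In this assay compound 1 gave only a limit, > 10000 nM. Compound 2 `CC(C)[C@H](NC(=O)c1cc(Cl)ccc1OCCCCN)C(=O)Nc1ccc([N+](=O)[O-])cc1Cl` differs from compound 1 by hydrogen in place of tert-butoxycarbonyl on an amine nitrogen. In this assay compound 2 gave 5590 nM. The step between them reads an at least 1.7-fold lower number from compound 1 to compound 2 (0.25 log units; that floor lies within the scatter); the step has only a floor because the limit of > 10000 nM in this assay, at which 2 of the 3 values shown sit, is where compound 1 sits.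

Compound 3 `CSCC[C@H](NC(=O)c1cc(Cl)ccc1OCCNC(=O)OC(C)(C)C)C(=O)Nc1ccc([N+](=O)[O-])cc1Cl` carries a different core from compound 1; the difference between the two cores is not broken down here. In this assay compound 3 gave only a limit, > 10000 nM. Compound 4 `CSCC[C@H](NC(=O)c1cc(Cl)ccc1OCCN)C(=O)Nc1ccc([N+](=O)[O-])cc1Cl` has not yet been measured in this assay and differs from compound 3 by hydrogen in place of tert-butoxycarbonyl on an amine nitrogen. Among the compounds with values here, the place is the same, an amine nitrogen whose other neighbours are a saturated chain carbon, so this is the same change as the one from compound 1 to compound 2.

In this assay the expected step is an at least 1.4-fold lower number from compound 3 to compound 4 (0.15 log units; that floor lies within the scatter), set beside the measured at least 1.7-fold lower number from compound 1 to compound 2 (0.25 log units; that floor lies within the scatter). The expectation for compound 4 rests on that step, an at least 1.7-fold lower number from compound 1 to compound 2 (0.25 log units; that floor lies within the scatter), since the same change was made. Compound 4 is therefore expected to give about 7000 nM in this assay, with a likely range from 3500 nM to 14000 nM, and there remains a fair chance that compound 4 again returns only a limit.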

Compound 4, half-maximal inhibitory concentration: > 10000 nM
Compound 4: a limit, no number (the forecaster's own chance of this, stated with the estimate: 45%); middle value at least 1.4-fold (0.15 log units) away from the limit.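

No step from compound 3 to compound 4 can be read in this assay, because both compounds give only a limit and no number: the limit of > 10000 nM in this assay, at which 3 of the 4 values shown sit.

The compounds shown leave open how strongly compound 3 and compound 4 inhibit, and whether hydrogen in place of tert-butoxycarbonyl has the same effect on the core of compound 3 as on the core of compound 1.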